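The source may report more compounds than this note shows. Statements on the series, on what has been measured and on what is new or still open speak of the compounds shown alone.

Compound 2 `N#Cc1nc2c(-c3nc4ccccc4[nH]3)c(N)n(CCO)c2nc1C#N` is one of two compounds already tested in a functional assay on HL60/MX2 cells (Homo sapiens) for antiproliferative activity, read by MTT assay, with a stated time of 48 h; on this read-out higher numbers stand for weaker inhibition and lower numbers for stronger inhibition. In this assay compound 2 gives > 50000 nM, which is a limit of the assay rather than a number. Compound 1 `Cn1c(N)c(-c2nc3ccccc3[nH]2)c2nc(C#N)c(C#N)nc21` gives > 50000 nM in this assay, again a limit. The step that the two limits leave unreadable from compound 1 to compound 2 therefore cannot be read, and the limit of > 50000 nM in this assay, at which 2 of the 2 values shown sit, shows where both values sit. Compound 3 `CCN(CC)CCCCn1c(N)c(-c2nc3ccccc3[nH]2)c2nc(C#N)c(C#N)nc21` differs from compound 2 by 2-(diethylamino)ethyl in place of hydroxy on a saturated chain carbon, two bonds along the chain from an aromatic nitrogen. Within the data shown here, no measured step bears on this change. Compound 3 is expected to give 30000 nM, with a range from 5000 nM to 100000 nM. Among the measured compounds shown here, the expected step of an at least 1.6-fold lower number from compound 2 to compound 3 (0.22 log units; that floor lies within the scatter) rests on no measured step.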

Compound 3, half-maximal inhibitory concentration: 1550 nM
For compound 3 the middle estimate is 19-fold (1.29 log units) above the measured one; the measured number lies below the stated range.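

The chain on the aromatic nitrogen can clearly change the read-out in this assay, as 2-(diethylamino)ethyl in place of hydroxy gives an at least 32-fold lower number from compound 2 to compound 3 (1.50 log units; beyond the scatter). Set against the shorter chain of compound 1, 3-(diethylamino)propyl in place of hydrogen gives an at least 32-fold lower number from compound 1 to compound 3 (1.50 log units; beyond the scatter). The earlier step could not be read, and the limit is what kept this change at the position out of view: the limit of > 50000 nM in this assay, at which 2 of the 3 values shown sit.

Going by these compounds, whether the step belongs to the diethylamino group or to the chain length remains open. A plain butyl chain, or a shorter chain ending in diethylamino, would separate the two.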